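The source may report more compounds than this note shows. Statements on the series, on what has been measured and on what is new or still open speak of the compounds shown alone.

compound 1 `O=C(NCc1ccc(S(=O)(=O)c2ccccc2)cc1)c1cc2ncccc2s1`: 81%
compound 2 `O=C(NCc1ccc(S(=O)(=O)c2ccccc2)cc1)c1ccc2nccn2c1`: 77%
compound 3 `O=C(NCc1ccc(S(=O)(=O)N2CCCCC2)cc1)c1ccn2ccnc2c1`: "not determined" (no result reported)

These results come from an ADME assay on microsomes from liver (Homo sapiens) for metabolic stability, read by LC-MS, with a stated time of 30 min, tested at 1 uM; on this read-out higher numbers stand for a more stable compound and lower numbers for a less stable compound. Among the measured compounds shown here, compound 2, at 77%, lies within the scatter of compound 1, the only other compound with a number, so the two cannot be told apart. Compound 3 has no result and offers no guidance.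

Compound 4 `O=C(NCc1ccc(S(=O)(=O)c2ccccc2)cc1)c1ccc2nncn2c1` keeps the rest of compound 2 and alters one part: a group of 9 heavy atoms (6 carbon, 3 nitrogen; one five-membered aromatic ring with 3 hetero atoms, one six-membered aromatic ring with 1 hetero atom) in place of a group of 9 heavy atoms (7 carbon, 2 nitrogen; one five-membered aromatic ring with 2 hetero atoms, one six-membered aromatic ring with 1 hetero atom), on a carbonyl carbon. The change sits on a carbonyl carbon, and the five-membered aromatic ring with 2 hetero atoms gives way to a five-membered aromatic ring with 3 hetero atoms.

For the measured compounds named here, only one measured step bears on this: a number 4 percentage points lower from compound 1 to compound 2 (within the scatter). It is a swap of a group on a carbonyl carbon too, and it stays within the scatter. Going by the values given here, it involves a different pair of groups, however, and no measured compound carries the group found in compound 4, so the evidence is thin. On that single step, no change beyond the scatter is expected in this assay.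

The expected step is a number 1 percentage points lower from compound 2 to compound 4 (within the scatter). For compound 4 the estimate is 76%, with an expected range from 58% to 90%.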

Compound 4, percent of the compound remaining: 96%
Estimate against measurement, compound 4: 20 percentage points below; measured number outside the range, above it.
By their numbers in this assay, from the lowest: compounds 2 and 1 (each within the scatter of the next); then compound 4.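

In this assay, the group on this carbonyl carbon can matter: a number 19 percentage points higher from compound 2 to compound 4 (beyond the scatter), while the earlier swap at the same place gave only a number 4 percentage points lower from compound 1 to compound 2 (within the scatter). The change is small on paper, as the group keeps its 9 heavy atoms and trades one carbon for one nitrogen, so the five-membered aromatic ring with 2 hetero atoms becomes a five-membered aromatic ring with 3 hetero atoms. The entering group also clears the group of the sulfur-containing compound, with a number 15 percentage points higher from compound 1 to compound 4 (beyond the scatter), which puts compound 4 highest of the three numbers in this series, though nothing measured here explains the gain.

Going by these compounds, it remains open whether the group in compound 4 would give a similar rise on a different molecule, such as one carrying the other end of compound 3, which has no result to compare. It is also unknown how the number would respond to a further substituent on the entering group, such as an amine or a methoxy group, so one step cannot yet define a trend at this position.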